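Aryl swap on the double-bonded carbon of the series

The source may report more compounds than this note shows. Statements on the series, on what has been measured and on what is new or still open speak of the compounds shown alone.

Two compounds of this series are in hand. Compound 1 `COc1ccc(/C=N/NC(=O)Nc2ccc(Oc3ccnc4cc(OCCCN5CCCCC5)c(OC)cc34)c(F)c2)cc1` and compound 2 `COc1cc2c(Oc3ccc(NC(=O)N/N=C/c4ccc(O)cc4)cc3F)ccnc2cc1OCCCN1CCCCC1` share one core and differ only by hydrogen in place of methyl on an oxygen on an aromatic ring. In a functional assay on MKN-45 cells (Homo sapiens) for cytotoxicity, read by MTT assay, with a stated time of 72 h (a higher number here means a weaker inhibitor, a lower number a stronger inhibitor), compound 1 gives 660 nM, and compound 2 gives 850 nM. The step of a 1.3-fold higher number from compound 1 to compound 2 (0.11 log units; within the scatter) stays within the scatter, so the two numbers are to be read as level. For the measured compounds named here, compound 2 thus holds one of two level numbers, with compound 1 its only neighbour.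

Compound 3 `COc1cc2c(Oc3ccc(NC(=O)N/N=C/c4cc5ccccc5[nH]4)cc3F)ccnc2cc1OCCCN1CCCCC1` is derived from compound 2 by 1H-indol-2-yl in place of 4-hydroxyphenyl on a carbon with a double bond to nitrogen. Going by the values given here, no measured step touches this part of the molecule; the single measured step concerns a different site and is itself within the scatter, so it offers no direction for the new change. The expectation in this assay is therefore a step of a 1.1-fold lower number from compound 2 to compound 3 (0.05 log units; within the scatter) without a clear direction, but with a wider uncertainty than the scatter alone, since the entering group replaces a ring bearing a hydrogen-bond acceptor with a two-ring system bearing none. Compound 3 is estimated at 750 nM, within a range from 250 nM to 2300 nM.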

Compound 3, half-maximal inhibitory concentration: 830 nM
The estimate for compound 3 lay 1.1-fold (0.04 log units) below the measured number; measured number inside the range.
By their numbers in this assay, from the lowest: compounds 1, 3 and 2 (each within the scatter of the next).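

Notes on the carbon with a double bond to nitrogen: in this assay the swap to 1H-indol-2-yl from 4-hydroxyphenyl gives a level reading (a 1.0-fold lower number from compound 2 to compound 3 (0.01 log units; within the scatter)), and the swap from 4-methoxyphenyl does the same (a 1.3-fold higher number from compound 1 to compound 3 (0.10 log units; within the scatter)). The earlier pair varied only the group on the oxygen of a single aromatic ring, whereas these steps change the ring itself: a five-membered aromatic ring with 1 hetero atom and a six-membered aromatic ring of carbon only enter, and across these three aryl groups the number does not separate beyond the scatter. No supporting data bear on this level reading, and its origin stays unexplained.

Still open, from the compounds shown here alone, is whether this position responds to anything other than an aryl group, such as an open butyl chain, or to a ring carrying an amine or a carboxylic acid, either of which might give a step beyond the scatter. Also open, going by these compounds, is whether the level reading for these three aryl groups would hold with a different chain on the oxygen of the shared core.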